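Chloro for dihydroxy on a fused bicyclic core

The source may report more compounds than this note shows. Statements on the series, on what has been measured and on what is new or still open speak of the compounds shown alone.

The account concerns three measured compounds and one awaiting measurement in an assay on cells for displacement of a labelled ligand from adenosine receptor A3 (Homo sapiens), read by scintillation counting and radioligand binding, with a stated time of 180 min, tested at 10 uM; on this read-out lower numbers stand for less inhibition and higher numbers for more inhibition at the one concentration tested (going by the name of the read-out). Compound 1, `Cn1cnc2c(N3CCCCC3)nc(-c3cccc(O)c3O)nc21`, gives 33.7% in this assay. Compound 2, `CN1CCN(c2nc(-c3ccc(Cl)c(Cl)c3)nc3c2ncn3C)CC1`, gives 35.3%, and this value and that of compound 1 lie within the scatter of each other, so no order between them can be read. Compound 3, `CN1CCN(c2nc(-c3ccc(Cl)c(C(F)(F)F)c3)nc3[nH]cnc23)CC1`, is reported only at a limit of this assay, > 80%; this is the limit of > 80% in this assay, at which 1 of the 3 values shown sits, and it is not a number.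

The compound still to be measured is compound 4, `Cn1cnc2c(N3CCCCC3)nc(-c3ccccc3Cl)nc21`. It differs from compound 1 in one place: 2-chlorophenyl in place of 2,3-dihydroxyphenyl on an aromatic carbon. Among the compounds with values here, no measured pair in this set makes the same change, so the direction and size of the step are uncertain. Compound 4 is expected to give 45% in this assay, between 15% and 75%, which means an estimated step of a number 11.3 percentage points higher from compound 1 to compound 4 (beyond the scatter) that may or may not exceed the scatter.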

Compound 4, a percentage reported as inhibition, at one concentration (the size of the read-out at that concentration, not a potency): 2.1%
Compound 4: middle estimate off by 42.9 percentage points, on the high side; the whole stated range lies above it.
By their numbers in this assay, from the lowest: compound 4; then compounds 1 and 2 (each within the scatter of the next). At a limit, above all of these: compound 3.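

Replacing 2,3-dihydroxyphenyl with 2-chlorophenyl on this aromatic carbon, between two ring nitrogen atoms, gives in this assay a number 31.6 percentage points lower from compound 1 to compound 4 (beyond the scatter). Within the data shown here, this is the first readable step in the set, and it shows that the read-out on the core of compound 1 responds to the group at this place. The group that leaves has 2 hydrogen-bond donors and 2 hydrogen-bond acceptors, the group that enters has 0 of each and adds chlorine, and nothing measured here assigns a cause to the step.

The compounds shown leave open whether the loss follows the departure of the hydroxyl groups or the arrival of the chlorine. On these data alone, how a phenyl ring bearing a single hydroxyl, a methoxy group or an amine would read at this place also remains open.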